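A Basic Side Chain Replaces the Ether on Compound 3

A few compounds are considered here, and "the series" means these few. Any claim that something is new, unique, unknown or untested is made for them only; others in the source may bear on it.

Three compounds share one core and differ in their outer rings. Compound 1 `CC[C@H](C)[C@H](N)CN(C(=O)[C@@H]1C[C@H]1c1ccc(OC)cc1)c1ccc(-c2ccccc2)cc1` is measured in a functional assay for agonist activity at G protein-coupled receptor 88 (Homo sapiens), read by HTRF and cAMP accumulation; a higher number here means that more compound is needed for the effect, a lower number that less compound is needed; for compound 1 the result is only a limit of the assay, > 25000 nM, a point at which (the limit of > 25000 nM in this assay, at which 1 of the 3 values shown sits). Compound 2 `CC[C@H](C)[C@H](N)CN(C(=O)[C@@H]1C[C@H]1c1cccc(C)c1)c1ccc(-c2ccccc2)cc1` gives 1200 nM. Compound 3 `CC[C@H](C)[C@H](N)CN(C(=O)[C@@H]1C[C@H]1c1ccccc1)c1ccc(-c2ccc(OC(C)C)cc2)cc1` gives 72 nM, the lowest of the two numbers recorded, a clear distance from compound 2. For the measured compounds named here, the one step that can be traced, an at least 20-fold lower number from compound 1 to compound 2 (1.31 log units; beyond the scatter), concerns the group on the small saturated ring and not the outer aromatic ring that changes next.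

Compound 4 `CC[C@H](C)[C@H](N)CN(C(=O)[C@@H]1C[C@H]1c1ccccc1)c1ccc(-c2ccc(CN(C)C)cc2)cc1` is not yet measured. The change is (dimethylamino)methyl in place of isopropoxy on an aromatic carbon. Going by the values given here, no measured step touches that ring, so nothing here points to a direction or a size. The step is therefore expected to be a 1.4-fold higher number from compound 3 to compound 4 (0.14 log units; within the scatter), within the usual scatter. For compound 4 the estimate in this assay is 100 nM, with a range from 20 nM to 500 nM.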

Compound 4, half-maximal effective concentration: 460 nM
For compound 4 the middle estimate is 4.6-fold (0.66 log units) below the measured one; low and high end bracket the measured number.
By their numbers in this assay, from the lowest: compound 3; then compound 4; then compound 2. At a limit, above all of these: compound 1.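

In this assay the outer aromatic ring now has a traced step of its own, and it is a 6.4-fold higher number from compound 3 to compound 4 (0.81 log units; beyond the scatter), so a change at this position does move the number. Isopropoxy and (dimethylamino)methyl have the same heavy-atom, hydrogen-bond donor and hydrogen-bond acceptor counts and neither carries a net charge, so those counts do not separate the two groups even though their numbers differ. Nothing measured here explains why the number rises.

The compounds shown leave open whether a primary amine, a carboxylic acid or a longer chain on this aromatic carbon would shift the number the same way. A single step also cannot show whether this swap would have a similar size with a different group on the small saturated ring.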